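The source may report more compounds than this note shows. Statements on the series, on what has been measured and on what is new or still open speak of the compounds shown alone.

Measured compounds:
compound 1 `O=C(Nc1cccc(-n2cc(-c3ccncc3)c(-c3cc(O)cc(Cl)c3)n2)c1)Nc1ccc(Cl)c(C(F)(F)F)c1` — -12%
compound 2 `O=C(Nc1cccc(-n2cc(-c3ccncc3)c(-c3cc(O)cc(Cl)c3)n2)c1)Nc1ccc(Cl)c(Cl)c1` — -3%
compound 3 `COc1cc(Cl)cc(-c2nn(-c3cccc(NC(=O)Nc4ccc(Cl)c(Cl)c4)c3)cc2-c2ccncc2)c1` — 12%

In a functional assay on HOP-62 cells (Homo sapiens) for inhibition, read by sulforhodamine B assay, with a stated time of 48 h, tested at 100 uM (on this read-out higher numbers stand for a weaker effect at the one concentration tested and lower numbers for a stronger effect), compound 3 stands highest of the three numbers. The two measured steps are a number 9 percentage points higher from compound 1 to compound 2 (within the scatter) and a number 15 percentage points higher from compound 2 to compound 3 (beyond the scatter). Compound 4 `COc1cc(Cl)cc(-c2nn(-c3cccc(NC(=O)c4cccc(C(F)(F)F)c4)c3)cc2-c2ccncc2)c1` differs from compound 3 by 3-(trifluoromethyl)phenyl in place of (3,4-dichlorophenyl)amino on a carbonyl carbon. For the measured compounds named here, neither measured step touches the carbonyl carbon, so neither bears directly on this change; the only guide is that a substituent change on the far aromatic ring gave a step within the scatter. Going by the values given here, with no step of this kind on record, the expected change is a number 2 percentage points lower from compound 3 to compound 4 (within the scatter), with wide uncertainty. Compound 4 is therefore estimated at 10%, in the range -15% to 35%.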

Compound 4, a percentage reported as activity, at one concentration (the size of the read-out at that concentration, not a potency): 83%
For compound 4 the middle estimate is 73 percentage points below the measured one; measured number above the stated range.
By their numbers in this assay, from the lowest: compounds 1 and 2 (each within the scatter of the next); then compound 3; then compound 4.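

In this assay, the substituent on the carbonyl carbon matters far more than the chloro for trifluoromethyl swap on an aromatic carbon (a number 71 percentage points higher from compound 3 to compound 4 (beyond the scatter), against a number 9 percentage points higher from compound 1 to compound 2 (within the scatter)). The change removes the amino nitrogen and alters the substituents on the aromatic ring in one step, so neither part can be credited alone. Nothing available here explains the size of this step.

Still open, from the compounds shown here alone, is whether 3-(trifluoromethyl)phenylamino on the carbonyl carbon reads closer to compound 3 or compound 4. Going by these compounds, how a methylene link in place of the amino nitrogen would read also remains open.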